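A Methoxymethyl Replacement Weighed Against Three Tolerance Limits

The source may hold more compounds than are shown below. What is called first, only, known or untested is meant among the compounds shown, and "the series" means these compounds.

compound 1 `COc1ccc(-c2nc(/C=C/c3cc4ccccc4nc3OC)no2)cc1` — > 220000 nM
compound 2 `COc1cccc(-c2nc(/C=C/c3cc4ccccc4nc3OC)no2)c1` — > 220000 nM
compound 3 `COc1nc2ccccc2cc1/C=C/c1noc(-c2cccc(Cl)c2)n1` — > 220000 nM

In an ADME assay on HepG2 cells (Homo sapiens) for cytotoxicity, read by sulforhodamine B assay, with a stated time of 48 h (a lower number here means that less compound is tolerated, a higher number that more compound is tolerated), compound 1 gives > 220000 nM, which is a limit of the assay and not a number. Compound 2 likewise reaches only a limit in this assay, > 220000 nM. Compound 3 too stops at a limit, > 220000 nM. Compound 1 therefore stands nowhere in particular among the three: all sit at the limit of > 220000 nM in this assay, at which 3 of the 3 values shown sit. The three measured steps, a step that the two limits leave unreadable from compound 1 to compound 2, a step that the two limits leave unreadable from compound 1 to compound 3 and a step that the two limits leave unreadable from compound 2 to compound 3, are accordingly unreadable, so no size can be attached to a change of the aromatic substituent on the shared core of compound 1.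

Compound 4 `COCc1nc(/C=C/c2cc3ccccc3nc2OC)no1` is the next case. Its change from compound 1 is methoxymethyl in place of 4-methoxyphenyl on an aromatic carbon. Within the data shown here, none of the measured steps bears on this change with a readable size, because each rests on (the limit of > 220000 nM in this assay, at which 3 of the 3 values shown sit). Among the measured compounds shown here, the only guidance is that every measured compound was tolerated up to the limit, so compound 4 is expected to do the same, with a number no higher from compound 1 to compound 4 (the limit leaves the size open) expected to be no step beyond the scatter. For compound 4 the estimate in this assay is 220000 nM, with a range from 100000 nM to 400000 nM, most likely reported again as a limit.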

Compound 4, half-maximal cytotoxic concentration: > 270000 nM
Compound 4: a limit, no number; the forecaster's own chance of this, stated with the estimate: 80%; middle value at least 1.2-fold (0.08 log units) away from the limit.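

In this assay compound 4 gives > 270000 nM, which is a limit of the assay and not a number. Its steps from compound 1, compound 2 and compound 3 therefore cannot be read: the limit of > 270000 nM in this assay, at which 1 of the 4 values shown sits.

The compounds shown leave open at what concentration any of them would stop being tolerated, and whether methoxymethyl in place of 4-methoxyphenyl changes that concentration at all.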